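This account rests on a few compounds, and the source may have more. Where it says the series, first, only, none or still open, it means among the compounds named here.

The measured compounds:

Compound 1, `COc1ccc2[nH]c(C)c(Br)c(=O)c2c1`, gives a value that is only a limit of the assay: > 37300 nM.
Compound 2, `Cc1[nH]c2ccc(Cl)cc2c(=O)c1Br`, gives 21700 nM.
Compound 3, `COc1ccc2[nH]c(C)c(Cc3ccccc3)c(=O)c2c1`, gives a value that is only a limit of the assay: > 23700 nM.

All three were tested in an ADME assay on J774 cells (Mus musculus) for cytotoxicity; a higher number here means that more compound is needed for the effect, a lower number that less compound is needed. Two of the three readings stop at a limit: compound 1 sits at the limit of > 37300 nM in this assay, at which 1 of the 3 values shown sits, and compound 3 sits at the limit of > 23700 nM in this assay, at which 1 of the 3 values shown sits. Going by the values given here, the one exchange that can be read is chloro in place of methoxy on an aromatic carbon, which gave an at least 1.7-fold lower number from compound 1 to compound 2 (0.23 log units; that floor lies within the scatter). The other exchange, (benzyl in place of bromo on an aromatic carbon), gave a step that the two limits leave unreadable from compound 1 to compound 3.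

Compound 4, `Cc1[nH]c2ccc(Cl)cc2c(=O)c1Cc1ccccc1`, has not yet been measured in this assay. Among the compounds with values here, it differs from compound 3 by chloro in place of methoxy on an aromatic carbon, and this is the same change as the one made from compound 1 to compound 2, at the same place on the ring. The cores of compound 3 and compound 4 differ from those of compound 1 and compound 2 by benzyl in place of bromo on an aromatic carbon.

Within the data shown here, for compound 4 the step is expected to be an at least 1.1-fold lower number from compound 3 to compound 4 (0.07 log units; that floor lies within the scatter), set beside an at least 1.7-fold lower number from compound 1 to compound 2 (0.23 log units; that floor lies within the scatter) as the only measured instance of this change, a step whose floor lies within the usual scatter. Since compound 3 gives only a limit, the starting point is itself uncertain, so a fairly wide range is estimated. Compound 4 is expected to give about 20000 nM, within roughly 8000 nM to 50000 nM.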

Compound 4, half-maximal effective concentration: > 35200 nM
Compound 4 ended at the assay's limit (the forecaster's own chance of this, stated with the estimate: 40%); middle value at least 1.7-fold (0.24 log units) away from the limit.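

In this assay, compound 4 gives > 35200 nM, which is a limit of the assay. Compound 3 gives > 23700 nM, also a limit, so the step between compound 3 and compound 4 cannot be read. The compounds shown leave open how far chloro in place of methoxy shifts the number when benzyl is present, and what actual values compound 3 and compound 4 would have.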